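The source may hold more compounds than are shown below. What is called first, only, known or untested is meant among the compounds shown, and "the series" means these compounds.

Three compounds share one core and differ only in the group attached to the benzamide ring. Compound 1 `COc1ccc(C(=O)Nc2ccc(C)c(-n3cc(-c4cccnc4)cn3)c2)cc1` carries a methoxy group there, compound 2 `Cc1ccc(NC(=O)c2ccc(CN3CCN(C)CC3)cc2)cc1-n1cc(-c2cccnc2)cn1` a (4-methylpiperazin-1-yl)methyl group, and compound 3 `CCN(CC)Cc1ccc(C(=O)Nc2ccc(C)c(-n3cc(-c4cccnc4)cn3)c2)cc1` a (diethylamino)methyl group. In a functional assay on K562 cells (Homo sapiens) for inhibition, read by MTT assay, with a stated time of 48 h (on this read-out higher numbers stand for weaker inhibition and lower numbers for stronger inhibition), compound 1 gives 18300 nM, compound 2 gives 1670 nM, and compound 3 gives 3260 nM. The change from methoxy to the basic side chains brought an 11-fold lower number from compound 1 to compound 2 (1.04 log units; beyond the scatter) and a 5.6-fold lower number from compound 1 to compound 3 (0.75 log units; beyond the scatter). Between the two basic side chains the difference was only a 2.0-fold higher number from compound 2 to compound 3 (0.29 log units; within the scatter), so compound 3 stands second highest of the three numbers, well apart from compound 1 but close to compound 2.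

Compound 4 `CCN1CCN(Cc2ccc(C(=O)Nc3ccc(C)c(-n4cc(-c5cccnc5)cn4)c3)cc2)CC1` is not yet measured. It differs from compound 3 by the change (4-ethylpiperazin-1-yl in place of diethylamino on a saturated chain carbon bound to an aromatic carbon). Among the compounds with values here, the one measured step that bears on it is the swap between compound 2 and compound 3, which stayed within the scatter. Running that swap in the other direction suggests a small drop in the number, if any, so the expected step is a 1.7-fold lower number from compound 3 to compound 4 (0.23 log units; within the scatter). On that basis compound 4 is expected to give about 1900 nM in this assay, most likely between 800 nM and 4500 nM.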

Compound 4, half-maximal inhibitory concentration: 2330 nM
For compound 4 the middle estimate is 1.2-fold (0.09 log units) below the measured one; low and high end bracket the measured number.
By their numbers in this assay, from the lowest: compounds 2, 4 and 3 (each within the scatter of the next); then compound 1.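

In this assay, the new side chain shows that this position tolerates more than one kind of amine: putting 4-ethylpiperazin-1-yl in place of the open-chain diethylamino gives a 1.4-fold lower number from compound 3 to compound 4 (0.15 log units; within the scatter), and a methyl in place of a hydrogen on the saturated chain carbon bound to the ring amine nitrogen gives a 1.4-fold higher number from compound 2 to compound 4 (0.14 log units; within the scatter), both within the scatter. The gap to the methoxy group holds up for a third amine, with a 7.9-fold lower number from compound 1 to compound 4 (0.90 log units; beyond the scatter), so all three amine side chains shown, whether open-chain or in a ring, stand clear of compound 1. No measurement here explains why these side chains differ from methoxy, or why swapping one amine for another changes so little.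

The compounds shown leave open whether the second ring nitrogen plays any part, which a morpholin-4-yl group, with an oxygen in its place, would help to test. They also leave open whether an amine is needed at all, since a carboxylic acid or a plain alkyl chain on the same carbon could be compared with these amines in this assay.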